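A few compounds are considered here, and "the series" means these few. Any claim that something is new, unique, unknown or untested is made for them only; others in the source may bear on it.

Measured so far:
compound 1, `NC1=NC2(CCOCC2)N(OCCCOc2ccccc2Br)C(N)=N1`: "not determined" (no result reported)
compound 2, `Cc1ccc(OCCCON2C(N)=NC(N)=NC23CCOCC3)cc1`: 56.8 nM

For the measured compounds named here, in an assay on isolated protein for inhibition of Dihydrofolate reductase (Homo sapiens), read by spectrophotometry, using NADPH, with stated times of 5 s and 6 min (on this read-out lower numbers stand for stronger inhibition and higher numbers for weaker inhibition), compound 2 gives the only number in the set; compound 1 has no result reported there. Compound 3, `NC1=NC2(CCOCC2)N(OCCCOc2ccc(Br)cc2)C(N)=N1`, is the next entry to be measured. It differs from compound 2 by bromo in place of methyl on an aromatic carbon. Going by the values given here, no step between measured compounds shows what such an exchange does here, so the expectation rests on compound 2 alone. The step from compound 2 to compound 3 is expected to stay within the scatter, a 1.1-fold lower number from compound 2 to compound 3 (0.06 log units; within the scatter). Compound 3 is therefore estimated at 50 nM, with a range from 20 nM to 150 nM.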

Compound 3, half-maximal inhibitory concentration: 32.5 nM
Compound 3: middle estimate off by 1.5-fold (0.19 log units), on the high side; low and high end bracket the measured number.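

In this assay, bromo in place of methyl on this aromatic carbon, para to a large group, gives a 1.7-fold lower number from compound 2 to compound 3 (0.24 log units; within the scatter), so the read-out does not separate the 4-methylphenoxy and 4-bromophenoxy forms. The position therefore accepts either group without a step beyond the scatter. Nothing at hand bears on a cause for this result.

Compound 1 carries its bromo at another place on the ring and has no result, so the effect of moving the bromo cannot be read. As far as these compounds go, what an amine or a carboxylic acid on this aromatic carbon would give remains open, as does a longer chain to the phenoxy group.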